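Trifluoromethyl Ketone Aryl Variation in an Alpha-Ketooxazole Series

The compounds below may be only part of what the source reports. "The series", "measured", "known", "first", "only" and "open" are said of these compounds alone.

Measured compounds: compound 1 `COc1ccccc1-c1cnc(C(=O)CCCCCCc2ccccc2)o1` gives 400 nM; compound 2 `O=C(CCCCCCc1ccccc1)c1ncc(-c2cccc(O)c2)o1` gives 50 nM; compound 3 `Nc1ccc(-c2cnc(C(=O)CCCCCCc3ccccc3)o2)cc1` gives 90 nM, all in an assay (Rattus norvegicus) for inhibition of Fatty-acid amide hydrolase 1 (Homo sapiens); a higher number here means a weaker inhibitor, a lower number a stronger inhibitor.

Compound 3 stands second highest of the three numbers, with compound 2 nearest and compound 1 furthest, the furthest gap being a 4.4-fold lower number from compound 1 to compound 3 (0.65 log units; beyond the scatter). Compound 4 `O=C(CCCCCCc1ccccc1)c1ncc(-c2ccc(C(=O)C(F)(F)F)cc2)o1` differs from compound 3 by (trifluoromethyl)carbonyl in place of amino on an aromatic carbon. Going by the values given here, no measured step changes this position in this way; the steps that touch the aryl group, an 8.0-fold lower number from compound 1 to compound 2 (0.90 log units; beyond the scatter) and a 1.8-fold higher number from compound 2 to compound 3 (0.26 log units; within the scatter), show only modest movement across three different substituents. The step to compound 4 in this assay is therefore expected to be small, a 1.3-fold higher number from compound 3 to compound 4 (0.12 log units; within the scatter), in either direction. Compound 4 is estimated at 120 nM, in the range 25 nM to 600 nM.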

Compound 4, inhibition constant: 65 nM
Compound 4: the middle estimate sits 1.8-fold (0.27 log units) above what was measured, within the range that was stated.
By their numbers in this assay, from the lowest: compounds 2, 4 and 3 (each within the scatter of the next); then compound 1.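

In this assay, putting (trifluoromethyl)carbonyl in place of amino on an aromatic carbon, para to a large group, gives a 1.4-fold lower number from compound 3 to compound 4 (0.14 log units; within the scatter). The earlier compounds shown here did not show that this place accepts a group of six heavy atoms with no hydrogen-bond donor without a change beyond the scatter, so the donor of the amino group is not needed for this reading. Nothing available explains why the two readings match. The compounds shown leave open whether a carboxylic acid or a nitrile in this place would read alike, and whether this holds with a longer chain than the shared one.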